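Working notes: chloro to methoxy in the series

The source may hold more compounds than are shown below. What is called first, only, known or untested is meant among the compounds shown, and "the series" means these compounds.

Values in a functional assay on L1210 cells (Mus musculus) for antiproliferative activity, read by sulforhodamine B assay, with a stated time of 48 h; a lower number here means a stronger inhibitor, a higher number a weaker inhibitor:
- compound 1 `O=C1NCCN1c1ccc(S(=O)(=O)Nc2cccc(Br)c2)cc1`: 99 nM
- compound 2 `O=C1NCCN1c1ccc(S(=O)(=O)Nc2cccc(Cl)c2)cc1`: 77 nM

Compound 2 holds the lower of the two numbers, but compound 1 lies within the scatter of it, so the pair gives no real order. Compound 3 `COc1cccc(NS(=O)(=O)c2ccc(N3CCNC3=O)cc2)c1` is next, with methoxy in place of chloro on an aromatic carbon, meta to a large group.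

Going by the values given here, only one measured step bears on this change, a 1.3-fold lower number from compound 1 to compound 2 (0.11 log units; within the scatter). Among the compounds with values here, it exchanges bromo for chloro, and no measured compound carries methoxy, so it is a weak guide. It suggests some tolerance for change at this place. A small move towards a higher number is expected, possibly no larger than the scatter, and the direction is uncertain. The estimated step is a 1.6-fold higher number from compound 2 to compound 3 (0.19 log units; within the scatter). Compound 3 is estimated at 120 nM, with an expected range from 45 nM to 320 nM.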

Compound 3, half-maximal inhibitory concentration: 240 nM
The estimate for compound 3 lay 2.0-fold (0.30 log units) below the measured number; the range from low to high includes it.
By their numbers in this assay, from the lowest: compounds 2 and 1 (each within the scatter of the next); then compound 3.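

In this assay, going by these compounds alone, the steps of a 3.1-fold higher number from compound 2 to compound 3 (0.49 log units; beyond the scatter) and a 2.4-fold higher number from compound 1 to compound 3 (0.38 log units; beyond the scatter) are the first beyond the scatter, though both are modest. This position therefore does not accept every replacement alike: compound 1 and compound 2 lie within the scatter of each other, while compound 3, with 3-methoxyphenyl and a hydrogen-bond acceptor in the entering group, carries a higher number than either. No measurement at hand accounts for this step.

With only two halogens and methoxy at this place, the compounds shown cannot tell whether the higher number goes with the oxygen or with methoxy as a whole. A methyl, a hydroxy or an amine at the same carbon would separate these readings, and a longer alkoxy chain would show whether the trend continues.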